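Dropping the trifluoromethyl from a dichloroacetamide

The source may hold more compounds than are shown below. What is called first, only, known or untested is meant among the compounds shown, and "the series" means these compounds.

Two dichloroacetamides built on a shared core have been tested in a functional assay on NCI-H460 cells (Homo sapiens) for cytotoxicity, read by MTT assay, with a stated time of 68 h; a higher number here means a weaker inhibitor, a lower number a stronger inhibitor. Compound 1 `O=C(Nc1cccc(-c2ccccc2C(F)(F)F)c1)C(Cl)Cl` carries a trifluoromethyl group, and in this assay compound 1 gives 7550 nM. Compound 2 `COc1ccc(-c2cccc(NC(=O)C(Cl)Cl)c2)cc1` carries a methoxy group instead, and in this assay compound 2 gives 43300 nM. Of these two numbers, compound 1 has the lower one, so it is the stronger inhibitor, and the gap to compound 2 lies beyond the usual scatter.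

Compound 3 `O=C(Nc1cccc(-c2ccccc2)c1)C(Cl)Cl` has not yet been measured. It differs from compound 1 in one place: hydrogen in place of trifluoromethyl on an aromatic carbon. The group is simply taken away, with nothing put in its place. Within the data shown here, no measured pair in this set shows directly what such a removal does. Given that compound 1 gives 7550 nM and that the only other change seen here, in compound 2, weakened inhibition, a modest loss on removing the trifluoromethyl is expected, though a result within the scatter would not surprise. The step from compound 1 to compound 3 is expected to be a 2.1-fold higher number from compound 1 to compound 3 (0.33 log units; beyond the scatter). For compound 3 the estimate in this assay is 16000 nM, within a range of 5000 nM to 50000 nM.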

Compound 3, half-maximal inhibitory concentration: 20200 nM
Beside the measured number, compound 3's estimate is 1.3-fold (0.10 log units) below it, and the stated range covers the measured number.
By their numbers in this assay, from the lowest: compound 1; then compound 3; then compound 2.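

Set against hydrogen, the trifluoromethyl ortho to a large group on compound 1 now has a direct comparison in this assay: its removal gives a 2.7-fold higher number from compound 1 to compound 3 (0.43 log units; beyond the scatter) and so shows that inhibition at this position is better with the group than without it. Removing the methoxy has the opposite outcome, with a 2.1-fold lower number from compound 2 to compound 3 (0.33 log units; beyond the scatter) showing that compound 2 is a weaker inhibitor than the compound with hydrogen in its place, so among these three compounds, adding a group to the bare compound 3 does not always move the number the same way. No measurement shown here explains why the two groups differ in this way.

As far as these compounds go, with only trifluoromethyl and hydrogen compared at this position, it remains open whether the gain is specific to trifluoromethyl or would also appear with a chlorine atom, a methyl group or an amine on the same aromatic carbon. A carboxylic acid or a longer chain there would test how broadly this position accepts other groups, and the printed values do not show whether any such change would go beyond the number of compound 1.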